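Furan-3-yl in Place of Thiophen-3-yl on Compound 1

A few compounds are considered here, and "the series" means these few. Any claim that something is new, unique, unknown or untested is made for them only; others in the source may bear on it.

Compounds measured in a functional assay on K562 cells (Homo sapiens), read by MTT assay, with a stated time of 72 h; a higher number here means a weaker inhibitor, a lower number a stronger inhibitor:
compound 1, `Nc1nc(N)c2c(-c3ccsc3)cn([C@@H]3O[C@H](CO)[C@@H](O)[C@H]3O)c2n1`: > 20000 nM, a limit of the assay
compound 2, `C#Cc1cn([C@@H]2O[C@H](CO)[C@@H](O)[C@H]2O)c2ncnc(OC)c12`: 300 nM
compound 3, `Cc1ncnc2c1c(-c1cccs1)cn2[C@@H]1O[C@H](CO)[C@@H](O)[C@H]1O`: > 20000 nM, a limit of the assay

Compound 1 stands at the edge of what this assay can report. Its value is a limit, not a number, and so its exact place among the three measured compounds cannot be fixed. Compound 3 likewise returns only a limit. Compound 2 alone gives a number in this assay. The evidence on the measured values thus reduces to one line: the limit of > 20000 nM in this assay, at which 2 of the 3 values shown sit. Among the compounds with values here, no step between measured compounds that differ in one place is available.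

Compound 4, `Nc1nc(N)c2c(-c3ccoc3)cn([C@@H]3O[C@H](CO)[C@@H](O)[C@H]3O)c2n1`, differs from compound 1 by a single change: furan-3-yl in place of thiophen-3-yl on an aromatic carbon. With compound 1 at a limit, there is no number from which a shift could be read, and the structural change is small. The expectation is therefore that compound 4 remains in the same region, most likely again at the limit. The estimate for compound 4 in this assay is 20000 nM, with a range from 8000 nM to 50000 nM. This corresponds to an expected step of a number no higher from compound 1 to compound 4 (the limit leaves the size open), none beyond the scatter.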

Compound 4, half-maximal inhibitory concentration: > 20000 nM
Compound 4: no number, only a limit; the forecaster's own chance of this, stated with the estimate: 75%; the middle value sits exactly at the limit.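

In this assay compound 4 returns > 20000 nM, which is a limit of the assay and not a number. Within the data shown here, compound 1 also gives only a limit, and no step from compound 1 to compound 4 can be read. The compounds shown leave open whether furan-3-yl and thiophen-3-yl on the shared core differ at all in potency.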